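Series notes: replacing the hydroxypropyl ether of compound 1

A few compounds are considered here, and "the series" means these few. Any claim that something is new, unique, unknown or untested is made for them only; others in the source may bear on it.

Among the measured compounds shown here, compound 1 `CCC(CC)(c1ccc(OCCCO)c(C)c1)c1ccc(OCC(O)C(C)(C)C)c(OCC(O)C(C)(C)C)c1` gives 76% in an assay on cells for binding affinity to vitamin D3 receptor (Homo sapiens), read by fluorescence, tested at 1 uM (a lower number here means less inhibition, a higher number more inhibition at the concentration tested (going by the name of the read-out)), the highest of the three numbers measured so far. Compound 2 `CCC(CC)(c1ccc(OCCCCCCO)c(C)c1)c1ccc(OCC(O)C(C)(C)C)c(OCC(O)C(C)(C)C)c1` gives 52%, a step of a number 24 percentage points lower from compound 1 to compound 2 (beyond the scatter). Compound 3 `CCC(CC)(c1ccc(OCCCC(=O)O)c(C)c1)c1ccc(OCC(O)C(C)(C)C)c(OCC(O)C(C)(C)C)c1` gives 14%, a step of a number 62 percentage points lower from compound 1 to compound 3 (beyond the scatter); the two lower compounds are separated by a number 38 percentage points lower from compound 2 to compound 3 (beyond the scatter). Compound 4 `CCC(CC)(c1ccc(OS(=O)(=O)c2ccc([N+](=O)[O-])cc2)c(C)c1)c1ccc(OCC(O)C(C)(C)C)c(OCC(O)C(C)(C)C)c1` is not yet measured; its difference from compound 1 is (4-nitrophenyl)sulfonyl in place of 3-hydroxypropyl on an oxygen on an aromatic ring. Neither measured step is the same change, but both alterations at this aromatic oxygen lowered inhibition, the carboxy one by much the larger amount. A drop beyond the scatter is therefore expected, its size uncertain. Compound 4 is estimated at 35%, range 10% to 65%, an expected step of a number 41 percentage points lower from compound 1 to compound 4 (beyond the scatter).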

Compound 4, a percentage reported as inhibition, at one concentration (the size of the read-out at that concentration, not a potency): 29%
Estimate against measurement, compound 4: 6 percentage points above, within the range that was stated.
By their numbers in this assay, from the lowest: compound 3; then compound 4; then compound 2; then compound 1.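

In this assay, the step to a (4-nitrophenyl)sulfonyl on the aromatic oxygen, with its aromatic ring and no hydrogen-bond donor, is large: a number 47 percentage points lower from compound 1 to compound 4 (beyond the scatter), so a large loss at this position is not confined to the carboxy-ended chain. Against the other two chains the new group sits in the middle, with a number 23 percentage points lower from compound 2 to compound 4 (beyond the scatter) and a number 15 percentage points higher from compound 3 to compound 4 (beyond the scatter), both beyond the scatter. Nothing available explains these differences.

Open, going by these compounds, is which part of the new group goes with the loss, the sulfonyl or the nitro-bearing ring. A plain phenylsulfonyl, a methylsulfonyl or a 3-aminopropyl chain on this oxygen would bear on that.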